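The compounds below may be only part of what the source reports. "The series", "measured", "known", "first", "only" and "open" are said of these compounds alone.

Compound 1, `Cc1ccc2c(=O)c(CSC(=S)N3CCCCC3)coc2c1`: 900 nM
Compound 2, `Cc1ccc2c(=O)c(CSC(=S)N(C(C)C)C(C)C)coc2c1`: 700 nM

Both were measured in a functional assay on HEp-2 cells (Homo sapiens) for antiproliferative activity, read by MTT assay, with a stated time of 72 h; on this read-out lower numbers stand for stronger inhibition and higher numbers for weaker inhibition. Going by the values given here, compound 1 has the higher of the two numbers, but its only neighbour, compound 2, sits within the usual scatter of it, so neither can be called the more potent. Among the compounds with values here, the one measured step, a 1.3-fold lower number from compound 1 to compound 2 (0.11 log units; within the scatter), swaps the amine on the thiocarbonyl carbon and stays inside the scatter.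

Compound 3, `O=c1c(CSC(=S)N2CCCCC2)coc2ccccc12`, is not yet measured. It differs from compound 1 in a single place: hydrogen in place of methyl on an aromatic carbon. Within the data shown here, no measured step touches that part of the molecule; the step between compound 1 and compound 2 concerns a different position, so there is no direct precedent. With nothing pointing either way, compound 3 is expected to land near compound 1 in this assay, estimated at 1000 nM with a range of 400 nM to 2500 nM. The expected step is a 1.1-fold higher number from compound 1 to compound 3 (0.05 log units; within the scatter), which is not beyond the scatter.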

Compound 3, half-maximal inhibitory concentration: 390 nM
For compound 3 the middle estimate is 2.6-fold (0.41 log units) above the measured one; measured number below the stated range.
By their numbers in this assay, from the lowest: compounds 3, 2 and 1 (each within the scatter of the next, the first and the last beyond it).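

Dropping the methyl from this aromatic carbon, leaving hydrogen, gives a 2.3-fold lower number from compound 1 to compound 3 (0.36 log units; beyond the scatter) in this assay, a modest change but the first in this set to lie beyond the scatter, whereas swapping the amine on the thiocarbonyl carbon gave only a 1.3-fold lower number from compound 1 to compound 2 (0.11 log units; within the scatter). So this position on the core can shift the number, and the methyl is not needed for the activity seen here, since the smaller compound 3 gives the lower number. Nothing available explains why this change lowers the number.

As far as these compounds go, it remains open whether a chlorine atom, a methoxy group or a longer chain on the same aromatic carbon would lower the number further or raise it. From the compounds shown here alone, it is also open whether replacing methyl with hydrogen would have a similar effect when diisopropylamino takes the place of piperidin-1-yl.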